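The source may report more compounds than this note shows. Statements on the series, on what has been measured and on what is new or still open speak of the compounds shown alone.

Working notes on the series. Compound 1 `O=C(Nc1ccccc1O)C1CCc2ccccc2N1C(=O)c1ccc(Cl)cc1` and compound 2 `O=C(Nc1ccccc1C(F)(F)F)C1CCc2ccccc2N1` share the same core. In a functional assay on PC-3 cells (Homo sapiens) for cytotoxicity, read by sulforhodamine B assay, with a stated time of 72 h (a higher number here means a weaker inhibitor of growth, a lower number a stronger inhibitor of growth), compound 1 gives 25100 nM. In this assay compound 2 gives 53300 nM, the highest of the two numbers, and the gap to compound 1 lies beyond the scatter. For the measured compounds named here, no single-point step joins these two. Compound 3 `O=C(Nc1ccccc1C(F)(F)F)C1CCc2ccccc2N1C(=O)c1ccccc1` differs from compound 2 by benzoyl in place of hydrogen on a nitrogen on an aromatic ring in a ring. With compound 1 at 25100 nM carrying an acyl on the same ring nitrogen, a modest move toward a lower number is expected, a 1.8-fold lower number from compound 2 to compound 3 (0.25 log units; within the scatter). Compound 3 is estimated at 30000 nM, expected between 10000 nM and 90000 nM.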

Compound 3, concentration for 50% growth inhibition: 5560 nM
Beside the measured number, compound 3's estimate is 5.4-fold (0.73 log units) above it, outside the stated range (below it).
By their numbers in this assay, from the lowest: compound 3; then compound 1; then compound 2.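

In this assay, benzoyl in place of hydrogen on this ring nitrogen gives a 9.6-fold lower number from compound 2 to compound 3 (0.98 log units; beyond the scatter) and so marks the position as one where a single change moves the number beyond the scatter. For the compounds shown here, the earlier pair, joined by no single-point step, could not show this. Nothing at hand accounts for the size of the step.

From the compounds shown here alone, whether the step belongs to the carbonyl or to the aromatic ring of benzoyl stays open. An acetyl or a benzyl group on the same nitrogen would separate the two.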